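Benzyl in place of dimethylaminophenyl on a triazole acetamide

The source may hold more compounds than are shown below. What is called first, only, known or untested is meant among the compounds shown, and "the series" means these compounds.

Measured so far:
compound 1 `CCCCCCCCCCCCn1nnc(C(C(=O)NC(C)(C)C)c2ccccc2)n1` with 3350 nM
compound 2 `CCCCCCCCCCCCn1nnc(C(C(=O)Nc2c(OC)cc(OC)cc2OC)c2ccc(N(C)C)cc2)n1` with 659 nM
compound 3 `CCCCCCCCCCCCn1nnc(C(C(=O)Nc2c(C(C)C)cccc2C(C)C)c2nnn[nH]2)n1` with > 5000 nM

All three share the same core and were tested in an assay on liver for inhibition of sterol O-acyltransferase 1 (Rattus norvegicus), using microsomes; a lower number here means a stronger inhibitor, a higher number a weaker inhibitor. Compound 1 gives 3350 nM in this assay. Compound 2 gives 659 nM, the lower of the two numbers, and the higher number of compound 1 lies beyond the scatter. For compound 3 this assay reports only a limit, > 5000 nM, and the same is told by the limit of > 5000 nM in this assay, at which 1 of the 3 values shown sits.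

Compound 4 `CCCCCCCCCCCCn1nnc(C(Cc2ccccc2)C(=O)Nc2c(OC)cc(OC)cc2OC)n1` has not yet been measured in this assay. It differs from compound 2 in one place: benzyl in place of 4-(dimethylamino)phenyl on a saturated chain carbon bound to an aromatic carbon and a carbonyl carbon. Among the measured compounds shown here, no step between two measured compounds isolates this change. Compound 1, which carries an unsubstituted phenyl at that carbon, sits higher than compound 2, so a weakening is expected, and the step of a 2.4-fold higher number from compound 2 to compound 4 (0.39 log units; beyond the scatter) is the estimate made here. Compound 4 is therefore expected to give about 1600 nM, with a range from 500 nM to 5000 nM.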

Compound 4, half-maximal inhibitory concentration: 490 nM
Estimate against measurement, compound 4: 3.3-fold (0.51 log units) above; measured number outside the range, below it.
By their numbers in this assay, from the lowest: compounds 4 and 2 (each within the scatter of the next); then compound 1. At a limit, above all of these: compound 3.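

In this assay, among the compounds shown here, this pair gives the first reading at this position, a 1.3-fold lower number from compound 2 to compound 4 (0.13 log units; within the scatter), which places the two compounds within the scatter of each other. On a saturated chain carbon bound to an aromatic carbon and a carbonyl carbon, then, benzyl can stand in place of 4-(dimethylamino)phenyl without a step beyond the scatter, even though benzyl brings no nitrogen and no hydrogen-bond acceptor. Compound 1 could not show this, as it differs from compound 2 in more than one place, and nothing measured here gives a reason for the result.

Still open, as far as these compounds go, is what a carboxylic acid, an amine or a longer chain ending in a phenyl ring would give at this carbon. For the compounds shown here, whether the step holds with a different group on the amide nitrogen, such as the one in compound 1, is also open.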